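The source may hold more compounds than are shown below. What is called first, only, known or untested is meant among the compounds shown, and "the series" means these compounds.

The set begins with three compounds that share one core and differ in the groups that hang from it. Compound 1 `COC(=O)c1nc(C)n(-c2cccc(C(F)(F)F)c2)n1` carries a methyl group and a trifluoromethyl-substituted phenyl ring; in a functional assay on NPC-TW01 cells (Homo sapiens) for inhibition, read by MTT assay, with a stated time of 72 h (a higher number here means a weaker inhibitor of growth, a lower number a stronger inhibitor of growth), compound 1 reaches only the limit of the assay, at > 100000 nM. Compound 2 `COC(=O)c1nc(C)n(-c2ccc(OC)cc2)n1` keeps the methyl group but bears a methoxy-substituted phenyl ring, and in this assay compound 2 gives 9920 nM. Compound 3 `CCCCc1nc(C(=O)OC)nn1-c1ccc(F)cc1` pairs a butyl group with a fluoro-substituted phenyl ring. In this assay compound 3 gives no number but only a limit, > 100000 nM. Among the measured compounds shown here, compound 3 thus sits at the limit of > 100000 nM in this assay, at which 2 of the 3 values shown sit, so its place among the three is not a ranked one: it is simply at the edge of what the assay can report, and the one measured number in the set belongs to compound 2.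

Compound 4 `COC(=O)c1nc(-c2ccoc2)n(-c2ccc(F)cc2)n1` is the next compound, not yet measured. It differs from compound 3 by one exchange: furan-3-yl in place of butyl on an aromatic carbon, counted as furan-3-yl in place of butyl on an aromatic carbon. For the measured compounds named here, no step between two measured compounds maps this exchange, so the expectation rests on the standing of compound 3 alone. Because compound 3 reports only > 100000 nM, the step from compound 3 to compound 4 is expected to be none beyond the scatter or at most a modest move toward stronger inhibition, as an at least 1.6-fold lower number from compound 3 to compound 4 (0.22 log units; that floor lies within the scatter). For compound 4 in this assay the estimate is 60000 nM, with a likely range from 8000 nM to 200000 nM, and a real chance that the assay again returns only a limit.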

Compound 4, concentration for 50% growth inhibition: 11700 nM
Beside the measured number, compound 4's estimate is 5.1-fold (0.71 log units) above it, within the range that was stated.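

Among the compounds shown here, at the aromatic carbon between two ring nitrogen atoms, the earlier compounds carried only methyl or butyl, so they gave no view of a ring at this place. In this assay, furan-3-yl in place of butyl gives an at least 8.5-fold lower number from compound 3 to compound 4 (0.93 log units; beyond the scatter), which shows that this position responds to the group it carries and that an aromatic ring here is compatible with a measured inhibition of growth. The size of that step has only a floor, since its starting value is a limit: the limit of > 100000 nM in this assay, at which 2 of the 4 values shown sit.

The compounds shown leave open whether the ring oxygen of furan-3-yl plays any part in this step, as neither a phenyl nor a furan-2-yl group appears at this place, and whether an amine or a shorter chain would serve as well. They also leave open whether furan-3-yl would behave in the same way alongside the methoxy-substituted phenyl ring of compound 2, and whether the methoxycarbonyl group could give way to a carboxylic acid or an amide.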